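Methyl Added to the Amide Phenyl: Expected Writhing Inhibition

The compounds below may be only part of what the source reports. "The series", "measured", "known", "first", "only" and "open" are said of these compounds alone.

Compound 1 `CC(=O)Oc1ccc(-c2ccc(F)cc2F)cc1C(=O)NC1CCCCC1` and compound 2 `CC(=O)Oc1ccc(-c2ccc(F)cc2F)cc1C(=O)Nc1ccccc1` share one core and differ only in the group on the amide-type nitrogen. In a functional assay on the whole organism (strain Kunming) for inhibition, with Mus musculus as the target, in the writhing test, at a dose of 40 mg/kg by the oral route (on this read-out higher numbers stand for more inhibition at the one dose given (going by the name of the read-out) and lower numbers for less inhibition), compound 1 gives 15.6% and compound 2 gives 8.9%; the step of a number 6.7 percentage points lower from compound 1 to compound 2 (within the scatter) keeps both within the scatter, so neither can be ranked against the other. Compound 3 `CC(=O)Oc1ccc(-c2ccc(F)cc2F)cc1C(=O)Nc1ccccc1C` follows from compound 2 by methyl in place of hydrogen on an aromatic carbon. Among the measured compounds shown here, no measured step touches the ring that carries the methyl, and the only known step is small, so no change beyond the scatter is expected. Compound 3 is estimated at 10%, between 0% and 25%. That means an expected step of a number 1.1 percentage points higher from compound 2 to compound 3 (within the scatter).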

Compound 3, a percentage reported as inhibition, in the whole organism at one dose (the size of the read-out at that dose, not a potency): 12.3%
Compound 3: middle estimate off by 2.3 percentage points, on the low side; the range from low to high includes it.
By their numbers in this assay, from the lowest: compounds 2, 3 and 1 (each within the scatter of the next).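

Methyl in place of hydrogen on an aromatic carbon, ortho to a large group, gives a number 3.4 percentage points higher from compound 2 to compound 3 (within the scatter) in this assay, so this position accepts the added methyl without a shift beyond the scatter. Replacing cyclohexyl with 2-methylphenyl on the amide-type nitrogen gives a number 3.3 percentage points lower from compound 1 to compound 3 (within the scatter), so these two groups cannot be told apart either. Nothing available explains these results. Still open, going by these compounds, is whether an amine or a carboxylic acid at this same place would move the number beyond the scatter.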